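Changing the halogen and its place on the phenyl ring

The compounds below may be only part of what the source reports. "The series", "measured", "known", "first", "only" and "open" are said of these compounds alone.

Compound 1 `CCCn1c(=O)[nH]c2nc(-c3ccc(S(=O)(=O)N4CCN(Cc5cccc(Br)c5)CC4)cc3)[nH]c2c1=O` carries a 3-bromobenzyl group on the ring nitrogen of its piperazine-like ring. In an assay on CHO cells for displacement of a labelled ligand from adenosine receptor A3 (Homo sapiens), read by scintillation counting, with a stated time of 45 min, in the presence of a further agent that is not named here (a lower number here means a stronger inhibitor, a higher number a weaker inhibitor), compound 1 gives > 1000 nM, which is a limit of the assay rather than a number. Compound 2 `CCCn1c(=O)[nH]c2nc(-c3ccc(S(=O)(=O)N4CCN(c5cccc(F)c5)CC4)cc3)[nH]c2c1=O` bears a 3-fluorophenyl group at the same ring nitrogen. In this assay compound 2 gives > 1000 nM, again a limit and not a number. The step that the two limits leave unreadable from compound 1 to compound 2 therefore cannot be sized; both values sit at the limit of > 1000 nM in this assay, at which 2 of the 2 values shown sit, so compound 2 stands at the limit with no measured number to build on. Compound 3 `CCCn1c(=O)[nH]c2nc(-c3ccc(S(=O)(=O)N4CCN(c5ccccc5Cl)CC4)cc3)[nH]c2c1=O` differs from compound 2 by 2-chlorophenyl in place of 3-fluorophenyl on an amine nitrogen in a ring. Among the compounds with values here, no measured step bears on this change in a readable way, because the only step, a step that the two limits leave unreadable from compound 1 to compound 2, is hidden by two limits. Compound 3 is expected to give 3000 nM, with a range from 1000 nM to 20000 nM. That expectation amounts to a step that the limit leaves unreadable from compound 2 to compound 3, and most likely the assay will again report only a limit.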

Compound 3, inhibition constant: > 1000 nM
Compound 3 was reported as a limit; the forecaster's own chance of this, stated with the estimate: 85%; the middle value lies beyond the limit too.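

In this assay compound 3 gives > 1000 nM, which is a limit and not a number. The steps joining compound 3 to compound 1 and to compound 2 cannot be read, since all three compounds share one limit: the limit of > 1000 nM in this assay, at which 3 of the 3 values shown sit. The compounds shown leave open how strong each inhibitor is, and whether changing the halogen or its place alters that at all.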